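A few compounds are considered here, and "the series" means these few. Any claim that something is new, unique, unknown or untested is made for them only; others in the source may bear on it.

Of the compounds shown here, three sharing one core have been read in a functional assay on KB cells (Homo sapiens) for antiproliferative activity, read by MTT assay, with a stated time of 48 h (on this read-out lower numbers stand for stronger inhibition and higher numbers for weaker inhibition), with the same outcome. In this assay compound 1 (`Cn1cc(C2=C(c3nn(CCCn4cncn4)c4ncccc34)C(=O)N(c3ccccc3)C2=O)c2ccccc21`) gives > 100000 nM as a limit of the assay, not a number. In this assay compound 3 (`Cn1cc(C2=C(c3nn(CCCN4CCCCC4)c4ncccc34)C(=O)N(c3ccccn3)C2=O)c2ccccc21`) gives > 100000 nM as a limit as well. Compound 2 (`Cn1cc(C2=C(c3nn(CCCn4cccc4)c4ncccc34)C(=O)NC2=O)c2ccccc21`) gives > 100000 nM as a limit too, so it has no number of its own and stands with the other two, as the limit of > 100000 nM in this assay, at which 3 of the 3 values shown sit, shows.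

Compound 4 (`CN(C)CCCn1nc(C2=C(c3cn(C)c4ccccc34)C(=O)NC2=O)c2cccnc21`) differs from compound 2 by dimethylamino in place of 1H-pyrrol-1-yl on a saturated chain carbon, three bonds along the chain from an aromatic nitrogen and so carries 3-(dimethylamino)propyl where compound 2 carries 3-(1H-pyrrol-1-yl)propyl. For the measured compounds named here, no measured pair in this assay shows what such a change does. Only a modest move toward stronger inhibition is expected, and the estimated at least 1.6-fold lower number from compound 2 to compound 4 (0.22 log units; that floor lies within the scatter) is measured against a limit rather than a number. This caution rests on compound 2, whose > 100000 nM is a limit. For compound 4 the expected value is 60000 nM with an estimated range from 15000 nM to 150000 nM and a real chance that the outcome is only a limit.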

Compound 4, half-maximal inhibitory concentration: > 100000 nM
Compound 4 ended at the assay's limit (the forecaster's own chance of this, stated with the estimate: 55%); middle value at least 1.6-fold (0.22 log units) from the limit.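

In this assay compound 4 gives > 100000 nM, a limit and not a number. Compound 2 also sits at a limit, so no step can be read between compound 2 and compound 4. The compounds shown leave open whether dimethylamino in place of 1H-pyrrol-1-yl changes inhibition at all.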